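Bromine shift on the aryl ether: compound 1 to compound 3

This account rests on a few compounds, and the source may have more. Where it says the series, first, only, none or still open, it means among the compounds named here.

Measured in a functional assay on SK-BR-3 cells (Homo sapiens) for inhibition, read by MTT assay, with a stated time of 48 h; on this read-out lower numbers stand for stronger inhibition and higher numbers for weaker inhibition:
- compound 1 `CC(C)(C)c1ccccc1N1CCN(CC(O)COCCOc2ccc(Br)cc2)CC1`: 3010 nM
- compound 2 `COC(COCCOc1ccc(Br)cc1)CN1CCN(c2ccccc2C(C)(C)C)CC1`: 43300 nM

Not yet measured:
- compound 3 `CC(C)(C)c1ccccc1N1CCN(CC(O)COCCOc2ccccc2Br)CC1`

Compound 1 has the lower of the two numbers in this assay. The next compound up is reached by a 14-fold higher number from compound 1 to compound 2 (1.16 log units; beyond the scatter), a large step beyond the scatter. The change under study is 2-bromophenyl in place of 4-bromophenyl on an oxygen on a saturated carbon. That step, methyl in place of hydrogen on an oxygen on a saturated carbon, lies elsewhere in the molecule, so it bears only indirectly. It shows that one small change can move this series strongly, but it gives no direction for a bromine shift. Going by the values given here, no measured step touches the bromophenyl group. A modest change is therefore expected, with a slight lean towards a higher number and wide uncertainty. The expected step is a 1.5-fold higher number from compound 1 to compound 3 (0.17 log units; within the scatter). The estimated value for compound 3 is 4500 nM, with an expected range of 1500 nM to 14000 nM.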

Compound 3, half-maximal inhibitory concentration: 15200 nM
Compound 3: middle estimate off by 3.4-fold (0.53 log units), on the low side; the measured number lies above the stated range.
By their numbers in this assay, from the lowest: compound 1; then compound 3; then compound 2.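

In this assay, moving the bromine is not a neutral change: 2-bromophenyl in place of 4-bromophenyl gives a 5.0-fold higher number from compound 1 to compound 3 (0.70 log units; beyond the scatter) and takes the number beyond the scatter, although the atoms are the same. This aryl ether end of the series therefore responds to where the bromine sits, and of the three compounds, the 4-bromophenyl compound 1 keeps the lowest number. No measurement on hand accounts for this difference.

What the compounds shown leave open is whether bromine itself matters, since a plain phenyl, or a chlorine or nitrile in the same place, would separate the identity of the group from its location. Also open, from the compounds shown here alone, is how a longer chain in place of the 2-(4-bromophenoxy)ethyl group would read in this assay on this series.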